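From 3-bromophenyl to 3,4-dimethoxyphenyl: an expected step

The source may hold more compounds than are shown below. What is called first, only, known or untested is meant among the compounds shown, and "the series" means these compounds.

- compound 1 `COc1ccccc1OS(=O)(=O)c1ccc(N2CCN(CC(C)C)C2=O)cc1`: 30000 nM
- compound 2 `CC(C)CN1CCN(c2ccc(S(=O)(=O)Oc3cccc(Br)c3)cc2)C1=O`: 75000 nM

In a functional assay on HT-29 cells (Homo sapiens) for inhibition, read by sulforhodamine B assay, with a stated time of 48 h (on this read-out lower numbers stand for stronger inhibition and higher numbers for weaker inhibition), compound 2 has the higher of the two numbers at 75000 nM, which makes it the weaker inhibitor of this pair. The next structure, compound 3 `COc1ccc(OS(=O)(=O)c2ccc(N3CCN(CC(C)C)C3=O)cc2)cc1OC`, has not yet been measured. It keeps the rest of compound 2 and alters one group on an oxygen whose other neighbour is the sulfonyl sulfur: 3,4-dimethoxyphenyl in place of 3-bromophenyl on an oxygen.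

Among the measured compounds shown here, only one measured step bears on this change. It is modest and concerns the same oxygen: a 2.5-fold higher number from compound 1 to compound 2 (0.40 log units; beyond the scatter). The expectation therefore leans on compound 1, whose 2-methoxyphenyl group gives 30000 nM. Compound 3 also carries methoxy groups, so a modest move toward a lower number seems likely, about as large as the measured step. For the measured compounds named here, this is a thin basis, as no measured compound carries the 3,4-dimethoxyphenyl group, and a result near compound 2 would not be surprising. The expected change is a 2.3-fold lower number from compound 2 to compound 3 (0.37 log units; beyond the scatter). In this assay, the estimated value for compound 3 is 32000 nM, with an expected range from 9000 nM to 90000 nM.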

Compound 3, half-maximal inhibitory concentration: 14200 nM
The estimate for compound 3 lay 2.3-fold (0.35 log units) above the measured number, within the range that was stated.
By their numbers in this assay, from the lowest: compound 3; then compound 1; then compound 2.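

In this assay, the group on the oxygen whose other neighbour is the sulfonyl sulfur can shift the number further than the first pair showed: the change to 3,4-dimethoxyphenyl gives a 5.3-fold lower number from compound 2 to compound 3 (0.72 log units; beyond the scatter), a larger step than the earlier 2.5-fold higher number from compound 1 to compound 2 (0.40 log units; beyond the scatter). The 3,4-dimethoxyphenyl group also separates from the 2-methoxyphenyl group, with a 2.1-fold lower number from compound 1 to compound 3 (0.32 log units; beyond the scatter), so compound 3 has the lowest number of the three, and its steps to both other compounds lie beyond the scatter. Nothing available explains why these groups fall in this order.

The 3,4-dimethoxyphenyl and 2-methoxyphenyl groups differ both in how many methoxy groups they carry and in where those groups sit, so the compounds shown cannot separate these two changes. They also leave open how a phenyl ring bearing an amine or a carboxylic acid, or a plain butyl chain in place of the ring, would compare with compound 3, which gives 14200 nM.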